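A few compounds are considered here, and "the series" means these few. Any claim that something is new, unique, unknown or untested is made for them only; others in the source may bear on it.

Measured so far in an assay on CHO cells for antagonist activity at transient receptor potential cation channel subfamily V member 1 (Homo sapiens), read by FLIPR; a higher number here means a weaker inhibitor, a lower number a stronger inhibitor:
compound 1, `CCCCN(C)c1cc(C(F)(F)F)ccc1CNC(=O)C(C)c1ccc(NS(C)(=O)=O)c(F)c1`: 1.2 nM
compound 2, `CC(C(=O)NCc1ccc(C(F)(F)F)cc1N1CCCC1)c1ccc(NS(C)(=O)=O)c(F)c1`: 2.3 nM
compound 3, `CC(C(=O)NCc1ccc(C(F)(F)F)cc1N1CCN(C2CCCCC2)CC1)c1ccc(NS(C)(=O)=O)c(F)c1`: 13.8 nM

Compound 3 gives the highest number of the three in this assay, with a 6.0-fold higher number from compound 2 to compound 3 (0.78 log units; beyond the scatter) and a 12-fold higher number from compound 1 to compound 3 (1.06 log units; beyond the scatter) both beyond the scatter, so it is the weakest inhibitor of the set. Compound 4, `CC(C(=O)NCc1ccc(C(F)(F)F)cc1OC1CCCCC1)c1ccc(NS(C)(=O)=O)c(F)c1`, is not yet measured; it differs from compound 3 by cyclohexyloxy in place of 4-cyclohexylpiperazin-1-yl on an aromatic carbon. The two steps that bear on this change are a 12-fold higher number from compound 1 to compound 3 (1.06 log units; beyond the scatter) and a 6.0-fold higher number from compound 2 to compound 3 (0.78 log units; beyond the scatter), which show that the larger group in compound 3 raised the number against the smaller amino groups. Compound 4 carries a smaller group again, though an ether rather than an amine, so a return part of the way toward compounds 1 and 2 is expected, giving an estimated 2.8-fold lower number from compound 3 to compound 4 (0.44 log units; beyond the scatter). Compound 4 is thus estimated at 5 nM, within a range of 1.5 nM to 20 nM.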

Compound 4, inhibition constant: 0.7 nM
Estimate against measurement, compound 4: 7.1-fold (0.85 log units) above, outside the stated range (below it).
By their numbers in this assay, from the lowest: compounds 4, 1 and 2 (each within the scatter of the next, the first and the last beyond it); then compound 3.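

The step of a 20-fold lower number from compound 3 to compound 4 (1.29 log units; beyond the scatter) shows that this position accepts a cyclohexane ring, so that ring alone does not account for the high number of compound 3 with its 4-cyclohexylpiperazin-1-yl group. Cyclohexyloxy also gives a 3.3-fold lower number from compound 2 to compound 4 (0.52 log units; beyond the scatter) and a 1.7-fold lower number from compound 1 to compound 4 (0.23 log units; within the scatter), so an amino nitrogen on this aromatic carbon is not required for a low number. Nothing measured beyond these numbers explains the change.

On these data alone, it remains open whether the ether oxygen or the cyclohexane ring accounts for the low number of compound 4. A cyclohexylamino, cyclohexylmethyl or methoxy group here would separate the two.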